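Swapping the amide substituent on compound 1: cyclohexyl to 3-fluorophenyl

The compounds below may be only part of what the source reports. "The series", "measured", "known", "first", "only" and "open" are said of these compounds alone.

In a functional assay on DU-145 cells (Homo sapiens) for inhibition, read by MTT assay, with a stated time of 24 h (a higher number here means a weaker inhibitor, a lower number a stronger inhibitor), compound 1 `CCOC(=O)C1=Cc2ccccc2OC1(OCc1cn(CC(=O)NC2CCCCC2)nn1)C(F)(F)F` gives 10200 nM, the lowest of the three numbers available. Compound 2 `O=C(O)C1=Cc2ccccc2OC1(OCc1cc(-c2ccc([N+](=O)[O-])cc2)no1)C(F)(F)F` gives 100000 nM and compound 3 `O=C(O)C1=Cc2ccccc2OC1(OCc1cc(-c2ccc3ccccc3c2)no1)C(F)(F)F` gives 141000 nM; between them lies a 1.4-fold higher number from compound 2 to compound 3 (0.15 log units; within the scatter), and both sit far above compound 1. Compound 4 `CCOC(=O)C1=Cc2ccccc2OC1(OCc1cn(CC(=O)Nc2cccc(F)c2)nn1)C(F)(F)F` is made from compound 1 by 3-fluorophenyl in place of cyclohexyl on an amide-type nitrogen. Going by the values given here, no measured pair covers this kind of change: the only step at hand concerns two aryl groups on a different part of another core and tells nothing about an amide nitrogen. With no guide, the number for compound 4 is expected to stay close to that of compound 1, the step of a 1.0-fold lower number from compound 1 to compound 4 (0.01 log units; within the scatter) being an expectation of little change. Compound 4 is therefore estimated at 10000 nM, within 3000 nM to 35000 nM.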

Compound 4, half-maximal inhibitory concentration: > 150000 nM
Compound 4: a limit, no number (the forecaster's own chance of this, stated with the estimate: 5%); middle value at least 15-fold (1.17 log units) away from the limit.
By their numbers in this assay, from the lowest: compound 1; then compounds 2 and 3 (each within the scatter of the next). At a limit, above all of these: compound 4.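

In this assay, the group on the amide-type nitrogen turns out to matter strongly: 3-fluorophenyl in place of cyclohexyl gives an at least 14-fold higher number from compound 1 to compound 4 (1.16 log units; beyond the scatter). Going by these compounds, the full size of this step stays unknown, since compound 4 reads as a limit and not as a number: the limit of > 150000 nM in this assay, at which 1 of the 4 values shown sits. So on this core, activity at this position does not carry over from a non-aromatic ring to this aromatic one.

A plain phenyl group on this nitrogen would separate the effect of the fluorine from that of the aromatic ring. A cyclopentyl group or a longer alkyl chain there would show whether other non-aromatic groups keep the activity.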